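This account rests on a few compounds, and the source may have more. Where it says the series, first, only, none or still open, it means among the compounds named here.

In an assay on HEK293 cells for displacement of a labelled ligand from NPC1-like intracellular cholesterol transporter 1 (Homo sapiens) (a higher number here means a weaker inhibitor, a lower number a stronger inhibitor), compound 1 `CC(C)(C)c1ccc(C(=O)N2CCC3(CC2)C(=O)N(CC(=O)N2CCNCC2)CN3c2ccccc2)cc1` gives 22000 nM, compound 2 `CC(C)(C)c1ccc(C(=O)N2CCC3(CC2)C(=O)N(CC(=O)NCCO)CN3c2ccccc2)cc1` gives 1000 nM, and compound 3 `CCOC(=O)C1CCN(C(=O)CN2CN(c3ccccc3)C3(CCN(C(=O)c4ccc(C(C)(C)C)cc4)CC3)C2=O)CC1` gives 3100 nM. Among these three numbers compound 3 stands second highest: its nearest neighbour is compound 2, a step of a 3.1-fold higher number from compound 2 to compound 3 (0.49 log units; beyond the scatter), and its furthest is compound 1, a step of a 7.1-fold lower number from compound 1 to compound 3 (0.85 log units; beyond the scatter).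

Compound 4 `CC(C)(C)c1ccc(C(=O)N2CCC3(CC2)C(=O)N(CC(=O)N2CCN(S(C)(=O)=O)CC2)CN3c2ccccc2)cc1` is the next compound, and it differs from compound 3 in one place: 4-(methylsulfonyl)piperazin-1-yl in place of 4-(ethoxycarbonyl)piperidin-1-yl on a carbonyl carbon. Compound 4 can also be read as compound 1 with its piperazin-1-yl capped by a methylsulfonyl group, so the steps leaving the bare piperazin-1-yl of compound 1 bear on it: a 22-fold lower number from compound 1 to compound 2 (1.34 log units; beyond the scatter) and a 7.1-fold lower number from compound 1 to compound 3 (0.85 log units; beyond the scatter). Both replacements of the bare piperazin-1-yl lowered the number beyond the scatter, so a capped piperazin-1-yl is expected to sit near compound 3 rather than back at compound 1, with a step of a 1.0-fold lower number from compound 3 to compound 4 (0.01 log units; within the scatter) expected to stay within the scatter. Compound 4 is therefore estimated at 3000 nM, in a range from 1000 nM to 10000 nM.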

Compound 4, half-maximal inhibitory concentration: 19000 nM
Compound 4: the middle estimate sits 6.3-fold (0.80 log units) below what was measured; the measured number lies above the stated range.
By their numbers in this assay, from the lowest: compound 2; then compound 3; then compounds 4 and 1 (each within the scatter of the next).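

In this assay, the methylsulfonyl group on the amine nitrogen of the ring does not carry the piperazin-1-yl of compound 1 towards the lower numbers of the other two replacements, since capping that nitrogen leaves the result within the scatter (a 1.2-fold lower number from compound 1 to compound 4 (0.06 log units; within the scatter)). On this carbonyl carbon, a capped six-membered ring is therefore not enough in itself: 4-(methylsulfonyl)piperazin-1-yl falls short of both 4-(ethoxycarbonyl)piperidin-1-yl (a 6.1-fold higher number from compound 3 to compound 4 (0.79 log units; beyond the scatter)) and (2-hydroxyethyl)amino (a 19-fold higher number from compound 2 to compound 4 (1.28 log units; beyond the scatter)). Nothing measured here explains these differences.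

From the compounds shown here alone, it remains open whether the ethoxycarbonyl group of compound 3 matters, which a carboxylic acid or a bare piperidin-1-yl at this place would test. Going by these compounds, it is also open whether an acetyl cap on the piperazin-1-yl would behave like methylsulfonyl.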